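Series notes: piperidin-1-yl on the carbonyl carbon

The source may hold more compounds than are shown below. What is called first, only, known or untested is meant among the compounds shown, and "the series" means these compounds.

In an ADME assay on HUVEC cells (Homo sapiens) for cytotoxicity, read by MTT assay, with a stated time of 72 h (on this read-out higher numbers stand for weaker inhibition and lower numbers for stronger inhibition), compound 1 `O=C(CCC(=O)OCCCCCCSc1ccc([N+](=O)[O-])c2nonc12)Nc1ccc(C(F)(F)F)cc1` gives 1390 nM and compound 2 `O=C(CCC(=O)OCCCCCCSc1ccc([N+](=O)[O-])c2nonc12)Nc1ccc(F)c(Cl)c1` gives 2320 nM, so the two stand within the scatter of each other. Compound 3 `O=C(CCC(=O)N1CCCCC1)OCCCCCCSc1ccc([N+](=O)[O-])c2nonc12` carries piperidin-1-yl in place of (3-chloro-4-fluorophenyl)amino on a carbonyl carbon, with piperidin-1-yl in place of (3-chloro-4-fluorophenyl)amino on a carbonyl carbon. Among the measured compounds shown here, the only measured step, a 1.7-fold higher number from compound 1 to compound 2 (0.22 log units; within the scatter), exchanges one substituted phenyl for another on an amide-type nitrogen. For the measured compounds named here, no measured step covers loss of the aromatic ring, so the expectation is loose. The estimated step is a 1.2-fold higher number from compound 2 to compound 3 (0.08 log units; within the scatter), and no shift beyond the scatter is expected. For compound 3 the expected value is 2800 nM, with an estimated range of 900 nM to 8500 nM.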

Compound 3, half-maximal inhibitory concentration: 1990 nM
Beside the measured number, compound 3's estimate is 1.4-fold (0.15 log units) above it; low and high end bracket the measured number.
By their numbers in this assay, from the lowest: compounds 1, 3 and 2 (each within the scatter of the next).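

In this assay, the step of a 1.2-fold lower number from compound 2 to compound 3 (0.07 log units; within the scatter) shows that this carbonyl carbon tolerates piperidin-1-yl in place of (3-chloro-4-fluorophenyl)amino, with both the aromatic ring and the amide hydrogen gone. The step of a 1.4-fold higher number from compound 1 to compound 3 (0.16 log units; within the scatter) reads the same way against (4-(trifluoromethyl)phenyl)amino, so among compound 1, compound 2 and compound 3 the number does not depend on an aromatic ring at this place. Nothing available bears on the reason for this result.

Going by these compounds, whether dimethylamino or a carboxylic acid on this carbonyl carbon would also stay within the scatter remains open.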